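The source may report more compounds than this note shows. Statements on the series, on what has been measured and on what is new or still open speak of the compounds shown alone.

Three measured compounds share one core and differ only in the chain on the five-membered ring with three nitrogens. Compound 1 `CCCCCCc1cn(C(c2ccccc2)c2cc3cc(Br)ccc3nc2OC)nn1` carries a hexyl chain, compound 2 `CCCCc1cn(C(c2ccccc2)c2cc3cc(Br)ccc3nc2OC)nn1` a butyl chain, and compound 3 `CCCc1cn(C(c2ccccc2)c2cc3cc(Br)ccc3nc2OC)nn1` a propyl chain. In an ADME assay on PC-3 cells (Homo sapiens) for cytotoxicity, read by sulforhodamine B assay, with a stated time of 48 h, tested at 10 uM (a higher number here means more inhibition at the concentration tested (going by the name of the read-out), a lower number less inhibition), compound 1 gives 2.32%, compound 2 gives 5.54% and compound 3 gives 8.3%. All three numbers are low, and the steps between them, a number 3.2 percentage points higher from compound 1 to compound 2 (within the scatter), a number 6 percentage points higher from compound 1 to compound 3 (within the scatter) and a number 2.8 percentage points higher from compound 2 to compound 3 (within the scatter), stay within the scatter, so compound 3 cannot be set apart from the other two on these numbers.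

Compound 4 `COc1nc2ccc(Br)cc2cc1C(c1ccccc1)n1cc(-c2cccc(F)c2)nn1` is made from compound 3 by the change (3-fluorophenyl in place of propyl on an aromatic carbon). For the measured compounds named here, the steps that bear on this place are those to compound 3, a number 6 percentage points higher from compound 1 to compound 3 (within the scatter) and a number 2.8 percentage points higher from compound 2 to compound 3 (within the scatter), and both were within the scatter, but each only shortened a chain; no measured step puts a ring onto this carbon, so the data give no direct guide for a ring there. The expectation is therefore a step of a number 1.7 percentage points higher from compound 3 to compound 4 (within the scatter), none beyond the scatter, with wide uncertainty. Compound 4 is estimated at 10%, in a range from 0% to 35%.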

Compound 4, a percentage reported as inhibition, at one concentration (the size of the read-out at that concentration, not a potency): 14.6%
Estimate against measurement, compound 4: 4.6 percentage points below, and the stated range covers the measured number.
By their numbers in this assay, from the lowest: compounds 1, 2, 3 and 4 (each within the scatter of the next, the first and the last beyond it).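

Compound 4 is the first of these compounds with a ring on this carbon of the five-membered ring, where the others carry only saturated chains, and in this assay the swap for 3-fluorophenyl gives a number 6.3 percentage points higher from compound 3 to compound 4 (within the scatter) and a number 9.1 percentage points higher from compound 2 to compound 4 (within the scatter), so it cannot be told apart from the propyl or butyl compound. Only the comparison with the hexyl compound clears the scatter, at a number 12.3 percentage points higher from compound 1 to compound 4 (beyond the scatter), a modest step, and compound 4 at 14.6% still shows little inhibition at the single concentration tested, so an aromatic ring at this place gives no strong effect here, though it also brings no loss against the three chains. No measurement at hand explains the step from hexyl to 3-fluorophenyl.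

The compounds shown leave open whether the ring alone or its fluorine accounts for the value of compound 4, a question that a plain phenyl group on the same carbon would address. They also leave open whether a ring carrying an amine or a carboxylic acid, or a short chain such as methyl, would give a number clearly beyond the scatter of this set.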